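Does Dropping the Methoxy Change Cytotoxicity?

This account rests on a few compounds, and the source may have more. Where it says the series, first, only, none or still open, it means among the compounds named here.

Of the compounds shown here, three built on one shared core have been tested in a functional assay on MM1.S cells (Homo sapiens) for cytotoxicity, read by MTT assay, with a stated time of 48 h; on this read-out lower numbers stand for stronger inhibition and higher numbers for weaker inhibition. Compound 1 `COc1cccc(NN=C2C(Cl)=C(Cl)C(Cl)=C2Cl)c1` returns only a limit of this assay, > 3000 nM, rather than a number. Compound 2 `CC(C)(C)OC(=O)NN=C1C(Cl)=C(Cl)C(Cl)=C1Cl` gives 600 nM in this assay, and compound 3 `ClC1=C(Cl)C(Cl)=C(Cl)C1=NNc1cc(Cl)cc(Cl)c1` gives 2000 nM. Among the values shown, compound 1 therefore stands at the limit of > 3000 nM in this assay, at which 1 of the 3 values shown sits, with no number of its own to compare against.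

Compound 4 `ClC1=C(Cl)C(Cl)=C(Cl)C1=NNc1ccccc1` differs from compound 1 in a single place: hydrogen in place of methoxy on an aromatic carbon. Going by the values given here, no measured pair of compounds tracks this change on its own, so its effect has to be guessed. Compound 1 offers only a limit. Compound 3, carrying other groups on the same ring, reaches 2000 nM, so a plain ring in compound 4 is expected to land near that region or somewhat weaker. The estimated step from compound 1 to compound 4 is a number no higher from compound 1 to compound 4 (the limit leaves the size open). For compound 4 the expected value is 3000 nM, with a likely range from 1000 nM to 10000 nM.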

Compound 4, half-maximal inhibitory concentration: 2000 nM
Beside the measured number, compound 4's estimate is 1.5-fold (0.18 log units) above it; the range from low to high includes it.
By their numbers in this assay, from the lowest: compound 2; then compounds 3 and 4 (each within the scatter of the next). At a limit, above all of these: compound 1.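

With hydrogen on this aromatic carbon, this assay yields a real number instead of a limit: compound 4 gives 2000 nM. Hydrogen in place of methoxy produces an at least 1.5-fold lower number from compound 1 to compound 4 (0.17 log units; that floor lies within the scatter), so removing the methoxy does not weaken the compound on this read-out, although the floor alone cannot show a true gain. Going by these compounds, the real size of the step stays unknown because compound 1 has no number of its own: the limit of > 3000 nM in this assay, at which 1 of the 4 values shown sits.

The compounds shown leave open whether a different group on this same carbon, such as an amine, a carboxylic acid or a longer chain like ethoxy, would lower the number further or raise it. They also leave open whether a number for compound 1 from a wider concentration range would turn this floor into a step beyond the usual scatter.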